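Nitro for methoxy on the aryl ring of compound 3

The compounds below may be only part of what the source reports. "The series", "measured", "known", "first", "only" and "open" are said of these compounds alone.

Compound 3 `COc1ccc(C2C(C#N)=C(N)N(c3ccc(S(N)(=O)=O)cc3)C3=C2C(=O)CCC3)cc1` is one of three analogues measured in a functional assay on Ehrlich cells (Mus musculus) for antiproliferative activity, read by trypan blue exclusion, with a stated time of 2 h, tested at 100 ug/mL; a higher number here means a stronger effect of the compound at the concentration tested, a lower number a weaker effect. In this assay compound 3 gives 100%, level with compound 1 `N#CC1=C(N)N(c2ccc(S(N)(=O)=O)cc2)C2=C(C(=O)CCC2)C1c1ccc(O)cc1`, which gives 100%; the two stand together at the top, while compound 2 `N#CC1=C(N)N(c2ccc(S(N)(=O)=O)cc2)C2=C(C(=O)CCC2)C1/C=C/c1ccccc1` gives 45%. The difference is a number 55 percentage points higher from compound 2 to compound 3 (beyond the scatter), and a number 55 percentage points lower from compound 1 to compound 2 (beyond the scatter). Compound 4 `N#CC1=C(N)N(c2ccc(S(N)(=O)=O)cc2)C2=C(C(=O)CCC2)C1c1ccc([N+](=O)[O-])cc1` is not yet measured; it differs from compound 3 in this way: nitro in place of methoxy on an aromatic carbon. The step that bears most on it is no change at the digits printed from compound 1 to compound 3 (within the scatter), where the group on the aromatic carbon also changed without effect; the large steps concern exchange of the whole aryl group for 2-phenylethenyl and do not fit the present change. Compound 4 is therefore expected to stay near the top, with an estimated step of a number 10 percentage points lower from compound 3 to compound 4 (within the scatter). For compound 4 the estimate is 90%, with a range from 55% to 100%.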

Compound 4, a percentage reported as activity, at one concentration (the size of the read-out at that concentration, not a potency): 100%
Compound 4: middle estimate off by 10 percentage points, on the low side; the measured number falls inside the stated range.
By their numbers in this assay, from the lowest: compound 2; then compounds 1, 3 and 4 (each within the scatter of the next).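

In this assay, nitro in place of methoxy gives no change at the digits printed from compound 3 to compound 4 (within the scatter), and nitro in place of hydroxy gives no change at the digits printed from compound 1 to compound 4 (within the scatter), so hydroxy, methoxy and nitro on this aromatic carbon cannot be told apart at the one concentration tested. The 4-nitrophenyl group also keeps the gap to the 2-phenylethenyl compound, with a number 55 percentage points higher from compound 2 to compound 4 (beyond the scatter), so that gap now holds for three substituted phenyl groups rather than two. Nothing given here explains why these three groups read alike.

With all three phenyl compounds on one number at a single concentration, the compounds shown cannot tell whether they would separate in a graded comparison. Going by these compounds, it also stays open whether an amine or a carboxylic acid on this aromatic carbon would hold the same level.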